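The compounds below may be only part of what the source reports. "The series", "measured", "known", "first", "only" and "open" are said of these compounds alone.

Three compounds have been measured so far:

compound 1, `ClCc1ccccc1Cn1cnc2c(Cl)nc(Cl)nc21`, 420 nM;
compound 2, `ClCc1ccccc1Cn1cnc2c(Cl)ncnc21`, 1410 nM;
compound 3, `ClCc1cccc(Cn2cnc3c(Cl)ncnc32)c1`, 2290 nM.

All three were run in a functional assay on SK-MEL-5 cells (Homo sapiens) for cytotoxicity, read by sulforhodamine B assay, with a stated time of 48 h; on this read-out higher numbers stand for weaker inhibition of growth and lower numbers for stronger inhibition of growth. Compound 1 and compound 2 share a core and differ in one place: chloro in place of hydrogen on an aromatic carbon. That change produced a 3.4-fold lower number from compound 2 to compound 1 (0.53 log units; beyond the scatter). Compound 3 is built from the same atoms as compound 2, joined differently; the difference between the two cores is not broken down here. In this assay compound 2 gives 1410 nM and compound 3 gives 2290 nM, and these two values lie within the scatter of each other.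

Compound 4, `ClCc1cccc(Cn2cnc3c(Cl)nc(Cl)nc32)c1`, has not yet been measured. It stands to compound 3 as compound 1 stands to compound 2: chloro in place of hydrogen on an aromatic carbon. The surroundings of the place are described in exactly the same words for both changes, so this is the same change, now made on the core of compound 3 rather than on the core of compound 2. Among the measured compounds shown here, only one measured example of the change exists, so the range of the expectation is kept wide.

On that basis compound 4 is expected to give 670 nM in this assay, with a likely range from 340 nM to 1400 nM. This estimate amounts to an expected step of a 3.4-fold lower number from compound 3 to compound 4 (0.53 log units; beyond the scatter), placed beside the measured one.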

Compound 4, concentration for 50% growth inhibition: 1580 nM
Compound 4: the middle estimate sits 2.4-fold (0.37 log units) below what was measured; measured number above the stated range.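

In this assay, placing chloro on an aromatic carbon between two ring nitrogen atoms on the core of compound 3 gave a 1.4-fold lower number from compound 3 to compound 4 (0.16 log units; within the scatter), so on this core the change cannot be told apart from the usual spread of repeated measurements. The step on this core can nonetheless not be called different from the one on the other core, since the gap between the two does not exceed what two such steps can show by chance: the same change on two cores in this assay, a 3.4-fold lower number (0.53 log units; beyond the scatter) from compound 2 to compound 1 and a 1.4-fold lower number (0.16 log units; within the scatter) from compound 3 to compound 4, 2.3-fold (0.36 log units) apart, within the scatter of two such steps. Among the compounds shown here, this shows that the two results are compatible with a single effect of similar size on both cores, but it does not show that the effect carries over, since only one of the two steps stands clear of the scatter and two pairs are too few to fix its size or to rule out a real dependence on the core.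

The compounds shown leave open whether an amine or a methoxy group at that same place, in place of chloro, would give a step of any size on either core. They also leave open whether a step of this kind would persist if the chloromethyl group gave way to a longer chain or to a hydroxymethyl group.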